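The source may report more compounds than this note shows. Statements on the series, on what has been measured and on what is new or still open speak of the compounds shown alone.

Measured so far in a functional assay (microsomes, liver) with Rattus norvegicus as the target; a lower number here means a stronger inhibitor, a higher number a weaker inhibitor:

Compound 1 `Cc1c(C)c2c(c(C)c1N)CC(C)(C)O2`: 760 nM
Compound 2 `Cc1c(C)c2c(c(C)c1N)CC(C)(CSc1ccncc1)O2`: 630 nM
Compound 3 `Cc1c(C)c2c(c(C)c1N)CC(C)(CSCc1ccccc1)O2`: 260 nM

At 260 nM, compound 3 has the lowest number of the three, and its gaps to the other two lie beyond the usual scatter. Compound 4 `CCCSCC1(C)Cc2c(C)c(N)c(C)c(C)c2O1` has not yet been measured. It keeps the shared core and the sulfur but has ethyl in place of phenyl on a saturated chain carbon bound to a sulfur, so benzyl becomes propyl (ethyl in place of phenyl on a saturated chain carbon bound to a sulfur).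

Among the measured compounds shown here, two measured steps bear on this. The step of a 1.2-fold lower number from compound 1 to compound 2 (0.08 log units; within the scatter) brings in the sulfur side chain. The closer guide is a 2.4-fold lower number from compound 2 to compound 3 (0.38 log units; beyond the scatter), which swaps the group on the sulfur and shows that such a swap can matter, though only modestly. For the measured compounds named here, no measured compound has a ring-free group on the sulfur, so this exact change is untested. Compound 1, which has no side chain, gives 760 nM, and this suggests a sensible upper side for the expectation.

A small move to a higher number is therefore expected, possibly within the scatter: a 1.3-fold higher number from compound 3 to compound 4 (0.10 log units; within the scatter). The estimated value for compound 4 is 330 nM, with an expected range from 130 nM to 750 nM.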

Compound 4, half-maximal inhibitory concentration: 280 nM
Estimate against measurement, compound 4: 1.2-fold (0.07 log units) above; the range from low to high includes it.
By their numbers in this assay, from the lowest: compounds 3 and 4 (each within the scatter of the next); then compounds 2 and 1 (each within the scatter of the next).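

In this assay the change from benzyl to propyl is a 1.1-fold higher number from compound 3 to compound 4 (0.03 log units; within the scatter), so at this place on the sulfur side chain a phenyl can give way to ethyl with no change that can be told from the scatter, and the first ring-free group behaves like benzyl. The propyl compound also keeps the distance from the other two: the swap of pyridin-4-yl for propyl on the sulfur is a 2.3-fold lower number from compound 2 to compound 4 (0.35 log units; beyond the scatter), and adding the whole propylsulfanyl group to the bare core gives a 2.7-fold lower number from compound 1 to compound 4 (0.43 log units; beyond the scatter), both modest steps. So a side chain on the sulfur lowers the number with either benzyl or propyl, and the exception is compound 2, whose pyridin-4-yl group stays within the scatter of compound 1.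

No supporting measurement is available to explain these numbers. Still open, going by these compounds, is how far this tolerance extends, for instance whether a longer chain such as hexyl, an amine or a carboxylic acid on the sulfur would give a number at the level of propyl and benzyl.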